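Pyrazoline series: fluoro to methoxy on the pendant aryl

This account rests on a few compounds, and the source may have more. Where it says the series, first, only, none or still open, it means among the compounds named here.

Measured so far:
compound 1 `COc1ccc(C2=NN(c3nc(-c4ccc(OC)cc4)cs3)C(c3ccc4c(c3)OCCO4)C2)cc1`, 3010 nM
compound 2 `Fc1ccc(C2=NN(c3nc(-c4ccc(Br)cc4)cs3)C(c3ccc4c(c3)OCCO4)C2)cc1`, 4110 nM

In a functional assay on B16-F10 cells (Mus musculus) for antiproliferative activity, read by MTT assay, with a stated time of 48 h (on this read-out higher numbers stand for weaker inhibition and lower numbers for stronger inhibition), compound 2 gives the higher of the two numbers, and compound 1 gives 3010 nM, a gap that stays within the scatter. Among the compounds with values here, no step between measured pairs differing in one place is available. Compound 3 `COc1ccc(C2=NN(c3nc(-c4ccc(Br)cc4)cs3)C(c3ccc4c(c3)OCCO4)C2)cc1` differs from compound 2 by methoxy in place of fluoro on an aromatic carbon. No step beyond the scatter is expected from compound 2 to compound 3, with the step of a 1.2-fold lower number from compound 2 to compound 3 (0.10 log units; within the scatter). For compound 3 in this assay the expected value is 3300 nM, between 1500 nM and 7500 nM.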

Compound 3, half-maximal inhibitory concentration: 2520 nM
Compound 3: the middle estimate sits 1.3-fold (0.12 log units) above what was measured, within the range that was stated.
By their numbers in this assay, from the lowest: compounds 3, 1 and 2 (each within the scatter of the next).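

Methoxy in place of fluoro, read as 4-fluorophenyl to 4-methoxyphenyl, gives a 1.6-fold lower number from compound 2 to compound 3 (0.21 log units; within the scatter) in this assay and so opens no gap at this position. Bromo in place of methoxy on an aromatic carbon gives a 1.2-fold lower number from compound 1 to compound 3 (0.08 log units; within the scatter) and likewise stays inside the scatter, so neither exchange separates these compounds. No measurement at hand bears on the reason for either step.

Going by these compounds, whether an amine or a carboxylic acid on this aromatic carbon would give a step beyond the scatter remains open.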